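The source may hold more compounds than are shown below. What is called first, only, known or untested is meant among the compounds shown, and "the series" means these compounds.

Of the compounds shown here, three that share one core have been measured in an ADME assay for permeability, using PAMPA, with a stated time of 30 min, at pH 7.4; a lower number here means that the compound crosses the layer more slowly, a higher number that the compound crosses the layer faster. Compound 1 `COc1cccc(CNCCCNc2ccnc3cc(Oc4ccc(Cl)cc4)ccc23)c1O` gives 317 10^-6 cm/s. Compound 2 `COc1cccc(CNCCCNc2ccnc3cc(CCC(C)C)ccc23)c1O` gives 23 10^-6 cm/s. Compound 3 `COc1cccc(CNCCCNc2ccnc3cc(Cc4ccc(F)cc4)ccc23)c1O` gives 23 10^-6 cm/s. On these numbers compound 3 stands level with compound 2 at the digits reported, and the two together form the low end of the set, while the gap to the remaining compound is large: a 14-fold lower number from compound 1 to compound 3 (1.14 log units; beyond the scatter) and, for the other low compound, a 14-fold lower number from compound 1 to compound 2 (1.14 log units; beyond the scatter).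

Compound 4 `COc1cccc(CNCCCNc2ccnc3cc(Cc4cccc(C(F)(F)F)c4)ccc23)c1O` has not yet been measured in this assay. It differs from compound 3 in one place: 3-(trifluoromethyl)phenyl in place of 4-fluorophenyl on a saturated chain carbon bound to an aromatic carbon. Going by the values given here, only one measured step touches this same place, and it was flat: no change at the digits printed from compound 2 to compound 3 (within the scatter). The two large steps already seen concern the group on the aromatic carbon of the core, not the saturated chain carbon, so they do not bear on this change. Among the compounds with values here, with the single relevant comparison showing nothing beyond the scatter, no step beyond the scatter is expected in this assay in either direction. Compound 4 is therefore estimated to give about 25 10^-6 cm/s, within a range of 10 10^-6 cm/s to 60 10^-6 cm/s. This expectation corresponds to a step of a 1.1-fold higher number from compound 3 to compound 4 (0.04 log units; within the scatter).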

Compound 4, apparent permeability: 23 10^-6 cm/s
Beside the measured number, compound 4's estimate is 1.1-fold (0.04 log units) above it, and the stated range covers the measured number.
By their numbers in this assay, from the lowest: compounds 2, 3 and 4 (each within the scatter of the next); then compound 1.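

In this assay, putting 3-(trifluoromethyl)phenyl in place of 4-fluorophenyl on a saturated chain carbon bound to an aromatic carbon gives no change at the digits printed from compound 3 to compound 4 (within the scatter), so a group of 10 heavy atoms with three fluorines reads the same here as one of 7 heavy atoms with a single fluorine. Until now, the flatness at this place rested on a single pair, but no change at the digits printed from compound 2 to compound 4 (within the scatter) adds a second aromatic group to the comparison with isobutyl, and all three groups now stand within the scatter of one another. Compound 4 also falls with the low compounds, with a 14-fold lower number from compound 1 to compound 4 (1.14 log units; beyond the scatter), so among these four compounds the large steps all involve the 4-chlorophenoxy group on an aromatic carbon, while changes on the chain carbon have produced none.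

No measurement available here accounts for this flat result or for the high number of compound 1. Going by these compounds, it remains open whether the level would hold with an amine, a carboxylic acid or a longer chain at this place, and whether a 3-(trifluoromethyl)phenoxy group on the aromatic carbon of the core would come close to compound 1, which gives 317 10^-6 cm/s here.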